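Swapping the bridged hydrocarbon for an acetylpiperidine

The source may hold more compounds than are shown below. What is called first, only, known or untested is meant among the compounds shown, and "the series" means these compounds.

Compound 1 `Cc1c(Cl)cccc1Oc1cccn2c(C34CCC(CC3)C4)nnc12` is the starting point of this account. Among the measured compounds shown here, in an ADME assay on microsomes from liver (Mus musculus) for metabolic stability, with a stated time of 10 min (a higher number here means that more of the compound is left, a lower number that less of the compound is left), compound 1 gives 57%, the lowest of the three numbers measured so far. Compound 2 `Cc1c(Cl)cccc1Oc1cccn2c(C3CCC(C)(O)CC3)nnc12` gives 97% in this assay, and compound 3 `Cc1c(Cl)cccc1Oc1cccn2c(C3CCOCC3)nnc12` gives 100%. The two measured steps away from compound 1 are both large: a number 40 percentage points higher from compound 1 to compound 2 (beyond the scatter) and a number 43 percentage points higher from compound 1 to compound 3 (beyond the scatter), each time when a six-membered non-aromatic ring carrying an oxygen replaces the two five-membered rings of carbon only. Between compound 2 and compound 3 the difference is a number 3 percentage points higher from compound 2 to compound 3 (within the scatter).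

Compound 4 `CC(=O)N1CCC(c2nnc3c(Oc4cccc(Cl)c4C)cccn23)CC1` has not yet been measured. It differs from compound 1 in one place: a group of 9 heavy atoms (7 carbon, 1 nitrogen, 1 oxygen; one six-membered non-aromatic ring with 1 hetero atom) in place of a group of 7 heavy atoms (7 carbon; 2 five-membered non-aromatic rings of carbon only), on an aromatic carbon. This change bears a close resemblance to the two measured steps, in that a six-membered non-aromatic ring with one hetero atom again takes the place of the bridged group. A large rise in this assay is therefore expected, of about a number 37 percentage points higher from compound 1 to compound 4 (beyond the scatter). The estimate for compound 4 is 94%, with a range from 78% to 100%.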

Compound 4, percent of the compound remaining: 90%
Compound 4: the middle estimate sits 4 percentage points above what was measured; the range from low to high includes it.
By their numbers in this assay, from the lowest: compound 1; then compounds 4, 2 and 3 (each within the scatter of the next).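

In this assay the 1-acetylpiperidin-4-yl group, with a ring nitrogen and a carbonyl that the earlier groups lack, gives a number 33 percentage points higher from compound 1 to compound 4 (beyond the scatter) at this place on the five-membered aromatic ring, so the large rise is not confined to groups carrying a ring oxygen or a hydroxy group. With a number 10 percentage points lower from compound 3 to compound 4 (within the scatter) and a number 7 percentage points lower from compound 2 to compound 4 (within the scatter), the three six-membered ring groups cannot be told apart in this assay and all three stand clear of the bridged hydrocarbon of compound 1 . No measurement at hand explains this difference.

The compounds shown leave open whether the piperidine without its acetyl, as a free amine, would fall with these three groups in this assay. They also leave open how a carboxylic acid on the six-membered ring would fare at this place.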